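Benzylamino amide on the shared core: cytotoxicity outlook

The source may hold more compounds than are shown below. What is called first, only, known or untested is meant among the compounds shown, and "the series" means these compounds.

Compound 1 (`CCCCNc1nc(N)nc2cccc(C(=O)NC)c12`), compound 2 (`CCCCNc1nc(N)nc2cccc(C(=O)NC(C)C)c12`) and compound 3 (`CCCCNc1nc(N)nc2cccc(C(=O)N(C)C(C)C)c12`) differ only at the amide. In an ADME assay on HEK293 cells (Homo sapiens) for cytotoxicity, with a stated time of 6 h (on this read-out lower numbers stand for higher toxicity in this test and higher numbers for lower toxicity in this test), compound 1 gives > 25000 nM as a limit. Compound 2 gives > 25000 nM as a limit. Compound 3 stands at > 25000 nM and this too is a limit. The measured steps are a step that the two limits leave unreadable from compound 1 to compound 2 then a step that the two limits leave unreadable from compound 1 to compound 3 and finally a step that the two limits leave unreadable from compound 2 to compound 3 and none gives a size.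

Compound 4 (`CCCCNc1nc(N)nc2cccc(C(=O)NCc3ccccc3)c12`) has benzylamino in place of isopropyl(methyl)amino on a carbonyl carbon. The expectation rests on compound 3 and its two relatives through the limit of > 25000 nM in this assay, at which 3 of the 3 values shown sit, and on nothing finer. The estimated change is a step that the limit leaves unreadable from compound 3 to compound 4 and no step beyond the scatter is expected in this assay in either direction. Compound 4 is expected at 30000 nM with an estimated range of 12000 nM to 60000 nM for now.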

Compound 4, half-maximal cytotoxic concentration: > 25000 nM
Compound 4 gave a limit, no number (the forecaster's own chance of this, stated with the estimate: 85%); the middle value lies beyond the limit too.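

In this assay compound 4 gives > 25000 nM, a limit, and its steps from compound 1, compound 2 and compound 3 cannot be read. The compounds shown leave open whether any amide change alters cytotoxicity.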